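The source may report more compounds than this note shows. Statements on the series, on what has been measured and on what is new or still open speak of the compounds shown alone.

Measured so far in an ADME assay on L6 cells (Rattus norvegicus) for cytotoxicity, read by resazurin assay, with a stated time of 72 h; a lower number here means a stronger inhibitor, a higher number a weaker inhibitor:
- compound 1 `N=C(N)c1ccc(OCc2ccc([N+](=O)[O-])cc2)c(I)c1` at 10700000 nM
- compound 2 `N=C(N)c1cc(I)c(OCc2cccc([N+](=O)[O-])c2)c(I)c1` at 7720000 nM
- compound 3 `N=C(N)c1cccc(OCc2ccccc2)c1` at 156000000 nM

Compound 3 has the highest number of the three, and its distance to each of the other two lies beyond the scatter. Compound 4 `N=C(N)c1cccc(OCc2cccc([N+](=O)[O-])c2)c1` is compound 3 with nitro in place of hydrogen on an aromatic carbon, meta to a large group (nitro in place of hydrogen on an aromatic carbon). Going by the values given here, no measured pair isolates this change. Compound 1 at 10700000 nM and compound 2 at 7720000 nM both carry nitro and both stand lower than compound 3, but each also differs from it elsewhere, so they offer only indirect support. Part of their distance from compound 3 is therefore expected to carry over, not all of it. An estimated step of a 4.5-fold lower number from compound 3 to compound 4 (0.65 log units; beyond the scatter) is expected in this assay toward a lower number, probably beyond the scatter. For compound 4 the expected value is 35000000 nM with an estimated range from 9000000 nM to 130000000 nM at this stage.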

Compound 4, half-maximal inhibitory concentration: 78900000 nM
Compound 4: the middle estimate sits 2.3-fold (0.35 log units) below what was measured, within the range that was stated.
By their numbers in this assay, from the lowest: compounds 2 and 1 (each within the scatter of the next); then compounds 4 and 3 (each within the scatter of the next).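

In this assay, going by these compounds alone, the step of a 2.0-fold lower number from compound 3 to compound 4 (0.30 log units; within the scatter) is the first direct reading of nitro in place of hydrogen on an aromatic carbon, meta to a large group, and it lies within the scatter. This single pair therefore gives nitro at this position no effect that can be told apart from repeat variation, and the indirect support from compounds 1 and 2 does not hold up here as a separate contribution from nitro. Nothing measured here speaks to the reason for this result.

From the compounds shown here alone, whether an amine or a carboxylic acid in place of hydrogen at this position would move the number beyond the scatter stays open. Within the data shown here, also open is how the distance of compounds 1 and 2 from compound 3 divides among their differences, with no pair here isolating iodine.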